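Flipping both ring centres of a melanocortin-4 ligand

A few compounds are considered here, and "the series" means these few. Any claim that something is new, unique, unknown or untested is made for them only; others in the source may bear on it.

Compound 1 `COc1ccc(-n2nc(Sc3ccc(Cl)cc3)cc(CC[C@@H](C)NC(=O)[C@H]3CNCC[C@@H]3c3cccc(Cl)c3)c2=O)cc1`; in an assay on CHO cells for binding affinity to Melanocortin receptor 4 (Homo sapiens) (on this read-out lower numbers stand for stronger inhibition and higher numbers for weaker inhibition), compound 1 gives 43 nM
Compound 2 `COc1ccc(-n2nc(Sc3ccc(Cl)cc3)cc(CC[C@@H](C)NC(=O)[C@H]3CCNC[C@@H]3c3ccc(Cl)cc3Cl)c2=O)cc1`; in this assay compound 2 gives 36 nM
Compound 3 `COc1ccc(-n2nc(Sc3ccc(Cl)cc3)cc(CC[C@@H](C)NC[C@H]3CNCC[C@@H]3c3ccc(F)cc3)c2=O)cc1`; in this assay compound 3 gives 28 nM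

Compound 3 has the lowest of the three numbers, but its gaps to compound 2 and to compound 1 both lie within the scatter, so the three compounds stand together and none can be called the strongest.

Compound 4 `COc1ccc(-n2nc(Sc3ccc(Cl)cc3)cc(CC[C@@H](C)NC[C@@H]3CNCC[C@H]3c3ccc(F)cc3)c2=O)cc1` keeps every atom and bond of compound 3 and differs only in configuration: the two compounds have the same atoms and bonds and differ only in configuration as drawn: 2 of 3 stereo elements differ; a stereocentre at a saturated ring carbon is drawn R in compound 3 and S in compound 4; a stereocentre at a saturated ring carbon is drawn S in compound 3 and R in compound 4. The stereocentre on the side chain is unchanged. Within the data shown here, no step between measured compounds involves such a change, so the expectation rests on the nature of the change alone. Inverting both ring centres together is expected to weaken binding in this assay by a step beyond the scatter, of uncertain size. Compound 4 is therefore expected to give 120 nM, with a range from 30 nM to 600 nM. The expected step is a 4.3-fold higher number from compound 3 to compound 4 (0.63 log units; beyond the scatter).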

Compound 4, half-maximal inhibitory concentration: 290 nM
The estimate for compound 4 lay 2.4-fold (0.38 log units) below the measured number, and the stated range covers the measured number.
By their numbers in this assay, from the lowest: compounds 3, 2 and 1 (each within the scatter of the next); then compound 4.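

Configuration at the two ring centres matters in this assay, a point compounds 1, 2 and 3 could not show because they differ in more than one place and stand within the scatter of one another. Inverting both centres together gives a 10-fold higher number from compound 3 to compound 4 (1.02 log units; beyond the scatter), so the binding read-out distinguishes these two mirror-related ring arrangements. With atoms and bonds unchanged, this gap can be assigned to configuration alone: the fact that compounds 3 and 4 differ only in the configuration as drawn.

The compounds shown leave open how much each ring centre contributes on its own. They also leave open whether the inversion would cost as much with a trifluoromethyl group in place of the fluorine.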